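Swapping an aryl group on a shared nitroimidazole-bearing core

The source may hold more compounds than are shown below. What is called first, only, known or untested is meant among the compounds shown, and "the series" means these compounds.

Compound 1 `C[C@]1(CN2CCc3nc(-c4ccc(OC(F)(F)F)cc4)ccc3C2)Cn2cc([N+](=O)[O-])nc2O1` carries a 4-(trifluoromethoxy)phenyl group, and in an ADME assay on Vero cells (Chlorocebus sabaeus) for cytotoxicity, read by MTT assay, with a stated time of 72 h (a higher number here means that more compound is tolerated, a lower number that less compound is tolerated), compound 1 gives "not determined" (no result reported), so no result is reported for it. Its relative compound 2 `C[C@]1(CN2CCc3nc(-c4cccc(Cl)c4F)ccc3C2)Cn2cc([N+](=O)[O-])nc2O1` was tested in this assay, and compound 2 gives > 32 ug/mL, which is a limit of the assay rather than a number, as noted in the limit of > 32 ug/mL in this assay, at which 1 of the 2 values shown sits. Compound 3 `C[C@]1(CN2CCc3nc(-c4ccc(Cl)cc4F)ccc3C2)Cn2cc([N+](=O)[O-])nc2O1` differs from compound 1 by 4-chloro-2-fluorophenyl in place of 4-(trifluoromethoxy)phenyl on an aromatic carbon. With no number for compound 1, the step cannot be sized; no step beyond the scatter is expected in this assay. Compound 3 is expected to give 40 ug/mL, between 20 ug/mL and 100 ug/mL.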

Compound 3, half-maximal cytotoxic concentration: > 32 ug/mL
Compound 3 ended at the assay's limit; the forecaster's own chance of this, stated with the estimate: 70%; the middle value does not contradict the limit.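

No step can be read from compound 2 to compound 3, because both results are limits and not numbers: the limit of > 32 ug/mL in this assay, at which 2 of the 3 values shown sit.

In this assay, as far as these compounds go, the true values of compound 2 and compound 3 stay open, as does the standing of compound 1.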